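The source may report more compounds than this note shows. Statements on the series, on what has been measured and on what is new or still open speak of the compounds shown alone.

Compound 3 `Cc1ccc(Cn2c(=O)[nH]c3c(N)nc(C(F)(F)F)cc32)nn1` is the compound from which the step here begins. In an in vitro ADME assay on microsomes from liver (Rattus norvegicus) for metabolic stability (a lower number here means slower removal, a higher number faster removal of the compound), compound 3 gives < 11 mL.min-1.g-1, and this is a limit of the assay, not a number. Compound 2 `Cc1ccc(Cn2c(=O)[nH]c3c(N)nc(C(F)(F)F)cc32)cn1` shares the core and the trifluoromethyl group with compound 3. In this assay compound 2 gives < 8.5 mL.min-1.g-1, which is also a limit. Compound 1 `Cc1ccc(Cn2c(=O)[nH]c3c(N)nc(-c4ncco4)cc32)cn1` carries 1,3-oxazol-2-yl where compound 2 carries trifluoromethyl. In this assay compound 1 gives < 8.5 mL.min-1.g-1, again a limit. Because all three results rest on the limit of < 8.5 mL.min-1.g-1 in this assay, at which 2 of the 3 values shown sit, or (the limit of < 11 mL.min-1.g-1 in this assay, at which 1 of the 3 values shown sits), the two measured steps, a step that the two limits leave unreadable from compound 1 to compound 2 and a step that the two limits leave unreadable from compound 2 to compound 3, have no readable size, and compound 3 cannot be placed above or below the other two on the numbers shown.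

Compound 4 `Cc1nc(Cn2c(=O)[nH]c3c(N)nc(C(F)(F)F)cc32)cs1` has not yet been measured. It differs from compound 3 in one place: 2-methyl-1,3-thiazol-4-yl in place of 6-methylpyridazin-3-yl on a saturated chain carbon bound to an aromatic nitrogen. Within the data shown here, no measured step covers an exchange of this kind, so the two unreadable steps offer no direction for it. With every result so far sitting at a limit, compound 4 is expected to give a step that the limit leaves unreadable from compound 3 to compound 4 that stays within the scatter, and a result of about 6 mL.min-1.g-1, estimated to lie between 3 mL.min-1.g-1 and 13 mL.min-1.g-1, is expected for compound 4.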

Compound 4, intrinsic clearance in microsomes: < 10 mL.min-1.g-1
Compound 4: a limit, no number; the forecaster's own chance of this, stated with the estimate: 70%; the middle value is on the limit's open side.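

In this assay compound 4 gives < 10 mL.min-1.g-1, which is a limit of the assay, not a number. Neither its step from compound 3 nor its step from compound 2 can be read. The compounds shown leave open how fast any of them is removed, and whether exchanging 6-methylpyridazin-3-yl, 6-methylpyridin-3-yl or 2-methyl-1,3-thiazol-4-yl changes that at all.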